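The source may report more compounds than this note shows. Statements on the series, on what has been measured and on what is new or still open speak of the compounds shown alone.

Three compounds share one core and differ only in the group on the benzyl ring. In a functional assay on the whole organism for inhibition, with Rattus norvegicus as the target, at a dose of 25 mg/kg by the intraperitoneal route (on this read-out lower numbers stand for less inhibition and higher numbers for more inhibition at the one dose given (going by the name of the read-out)), compound 1 `CN(C)c1ncnc2c1ncn2Cc1ccc(F)cc1` gives 21%. Compound 2 `CN(C)c1ncnc2c1ncn2Cc1ccc(Cl)cc1` gives 0%, and compound 3 `CN(C)c1ncnc2c1ncn2Cc1ccc(C#N)cc1` gives 0%. Compound 3 thus stands level with compound 2 at the digits shown, the two of them together the lowest of the three numbers; a number 21 percentage points lower from compound 1 to compound 3 (beyond the scatter) is a step beyond the scatter, while no change at the digits printed from compound 2 to compound 3 (within the scatter) lies within it.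

Compound 4 `CC(=O)Nc1ccc(Cn2cnc3c(N(C)C)ncnc32)cc1` is the next member: acetamido in place of cyano on an aromatic carbon. Among the compounds with values here, no measured step introduces acetamido, so the bearing steps are only those that set compound 3 where it is, namely a number 21 percentage points lower from compound 1 to compound 3 (beyond the scatter) and no change at the digits printed from compound 2 to compound 3 (within the scatter). Within the data shown here, because compound 3 gives 0% and there is no precedent for a rise, the expectation is a number 5 percentage points higher from compound 3 to compound 4 (within the scatter), none beyond the scatter. Compound 4 is therefore estimated at 5%, in the range 0% to 20%.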

Compound 4, a percentage reported as inhibition, in the whole organism at one dose (the size of the read-out at that dose, not a potency): 0%
Beside the measured number, compound 4's estimate is 5 percentage points above it; measured number inside the range.
By their numbers in this assay, from the lowest: compounds 2, 3 and 4 (each within the scatter of the next); then compound 1.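

In this assay, acetamido on an aromatic carbon para to a large group gives no change at the digits printed from compound 3 to compound 4 (within the scatter) and no change at the digits printed from compound 2 to compound 4 (within the scatter) even though it brings in a hydrogen-bond donor that cyano lacks. Chloro, cyano and acetamido, which differ in size and in hydrogen-bond donors, now all read alike at this position, and the change from the fluoro group gives a number 21 percentage points lower from compound 1 to compound 4 (beyond the scatter), the same gap as for the other two. Nothing in the data given explains why compound 1 alone stands apart from compounds 2, 3 and 4.

The compounds shown leave open how an amine, a hydroxyl or a carboxylic acid would read at this position. They also leave open whether a methoxy or trifluoromethyl group would stay with fluoro or with the other three groups.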